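A few compounds are considered here, and "the series" means these few. Any claim that something is new, unique, unknown or untested is made for them only; others in the source may bear on it.

Measured so far:
- compound 1, `O=C(/C=C/c1ccccc1)c1ccc(N2CCN(c3ccc(Cl)c(Cl)c3)CC2)cc1`: 13.4%
- compound 2, `Cc1ccc(N2CCN(c3ccc(C(=O)/C=C/c4ccccc4)cc3)CC2)cc1`: 2.85%
- compound 3, `O=C(/C=C/c1ccccc1)c1ccc(N2CCN(c3ccccc3)CC2)cc1`: 3.71%

In a functional assay on the whole organism (strain Kunming) for inhibition, with Mus musculus as the target, with a stated time of 1 h, at a dose of 40 mg/kg by the oral route (a lower number here means less inhibition, a higher number more inhibition at the dose given (going by the name of the read-out)), compound 1 gives 13.4%, the highest of the three numbers; its gap to compound 3 lies within the scatter, while its gap to compound 2 lies just beyond it. Compound 4, `O=C(/C=C/c1ccccc1)c1ccc(N2CCN(S(=O)(=O)c3ccc(Cl)cc3)CC2)cc1`, has not yet been measured. It differs from compound 1 in one place: (4-chlorophenyl)sulfonyl in place of 3,4-dichlorophenyl on an amine nitrogen in a ring.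

Among the compounds with values here, two measured steps bear on this change, since both also remove the 3,4-dichlorophenyl from the same ring nitrogen. The step of a number 10.6 percentage points lower from compound 1 to compound 2 (beyond the scatter) and the step of a number 9.7 percentage points lower from compound 1 to compound 3 (within the scatter) both point downward, and the pair of compounds 2 and 3 shows that what enters in their place made little difference: a number 0.9 percentage points higher from compound 2 to compound 3 (within the scatter). Nothing measured here tells how a sulfonyl-linked group behaves at that position, so the expectation rests on the two downward steps alone. On that basis a modest lowering is expected, a number 7.4 percentage points lower from compound 1 to compound 4 (within the scatter), and compound 4 is estimated at 6%, within a range from 0% to 16%.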

Compound 4, a percentage reported as inhibition, in the whole organism at one dose (the size of the read-out at that dose, not a potency): 46.8%
Compound 4: middle estimate off by 40.8 percentage points, on the low side; measured number above the stated range.
By their numbers in this assay, from the lowest: compounds 2, 3 and 1 (each within the scatter of the next, the first and the last beyond it); then compound 4.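

In this assay, within the data shown here, the group on this ring nitrogen proves able to change the result far more than the earlier compounds showed, since swapping among the 3,4-dichlorophenyl, 4-methylphenyl and phenyl groups kept every number well under that of compound 4. The (4-chlorophenyl)sulfonyl group gives a large rise against each of them: (a number 33.4 percentage points higher from compound 1 to compound 4 (beyond the scatter)), (a number 43.1 percentage points higher from compound 3 to compound 4 (beyond the scatter)) and (a number 44 percentage points higher from compound 2 to compound 4 (beyond the scatter)), which makes compound 4 the highest of the four. No measurement given here accounts for this rise.

This change brings in the sulfonyl link and also alters the chlorine pattern on the ring, so the compounds shown cannot say which of the two matters. A plain phenylsulfonyl group, a methylsulfonyl group or a benzoyl group, with a carbonyl as the link, would help separate the link from the ring.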